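Acetoxy for 2,5-dioxopyrrolidin-1-yl: expected cytotoxicity

The source may report more compounds than this note shows. Statements on the series, on what has been measured and on what is new or still open speak of the compounds shown alone.

Compound 2 `O=C1CCC(=O)N1C[C@H]1CN(c2ccc(-n3cc(-c4ccccn4)cn3)c(F)c2)C(=O)O1` stands in an ADME assay on HEK293-A cells (Homo sapiens) for cytotoxicity, read by MTT assay, with a stated time of 48 h (a higher number here means a weaker inhibitor, a lower number a stronger inhibitor), at a limit rather than a number, > 400 ug/mL (the limit of > 400 ug/mL in this assay, at which 1 of the 2 values shown sits). Compound 1 `CCN1CCN(C[C@H]2CN(c3ccc(-n4cc(-c5ccccn5)cn4)c(F)c3)C(=O)O2)CC1` gives 99 ug/mL in this assay. Among the compounds with values here, the only measured step, an at least 4.0-fold higher number from compound 1 to compound 2 (0.60 log units; beyond the scatter), concerns a different replacement at the same place. Compound 3 `CC(=O)OC[C@H]1CN(c2ccc(-n3cc(-c4ccccn4)cn3)c(F)c2)C(=O)O1` differs from compound 2 by acetoxy in place of 2,5-dioxopyrrolidin-1-yl on a saturated chain carbon bound to a saturated ring carbon. Within the data shown here, no measured step covers this change, so no shift beyond the scatter is expected in this assay. Compound 3 is expected at 300 ug/mL, within a range from 120 ug/mL to 600 ug/mL. This corresponds to an expected step of an at least 1.3-fold lower number from compound 2 to compound 3 (0.12 log units; that floor lies within the scatter).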

Compound 3, half-maximal inhibitory concentration: > 400 ug/mL
Compound 3: a limit, no number; the forecaster's own chance of this, stated with the estimate: 45%; middle value at least 1.3-fold (0.12 log units) from the limit.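

In this assay compound 3 reads > 400 ug/mL, a limit and not a number. With acetoxy as a second replacement for 4-ethylpiperazin-1-yl, the change gives an at least 4.0-fold higher number from compound 1 to compound 3 (0.60 log units; beyond the scatter), so the shift no longer rests on 2,5-dioxopyrrolidin-1-yl alone. The step between compound 2 and compound 3 cannot be read, and the limit now holds for both: the limit of > 400 ug/mL in this assay, at which 2 of the 3 values shown sit.

Going by these compounds, only compound 1 gives a number, so the true values of compound 2 and compound 3 stay open. Also open, on these data alone, is whether a simple amine, a hydroxyl or a carboxylic acid on the same saturated chain carbon would follow compound 1 or compound 3.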